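Benzyl in place of 4,4-dimethylcyclohexyl: outlook for compound 4

The compounds below may be only part of what the source reports. "The series", "measured", "known", "first", "only" and "open" are said of these compounds alone.

compound 1 `Cc1cc(NC(=O)Cn2nnc(-c3ccccc3)n2)n(C2CCC(C)(C)CC2)n1` — > 19%
compound 2 `CC1(c2cc(NC(=O)Cn3nnc(-c4ccccc4)n3)n(C3CCCCC3)n2)CC1` — > 10%
compound 3 `O=C(Cn1nnc(-c2ccccc2)n1)Nc1cc(C2CC2)nn1C1CCCCC1` — 45%

In an assay on HEK293 cells for activation of Kir3.1/Kir3.2 (Homo sapiens), read by thallium flux (a higher number here means a larger maximal response, a lower number a smaller maximal response), compound 1 gives > 19%, which is a limit of the assay and not a number; it sits at the limit of > 19% in this assay, at which 1 of the 3 values shown sits. Compound 2 gives > 10%, also a limit, namely (the limit of > 10% in this assay, at which 1 of the 3 values shown sits). Within the data shown here, compound 3 gives 45%, the only read number in the set. Among the measured compounds shown here, the sole step between measured compounds, a step that the limit leaves unreadable from compound 2 to compound 3, stays unreadable, so no measured step bears on the change to compound 4 `Cc1cc(NC(=O)Cn2nnc(-c3ccccc3)n2)n(Cc2ccccc2)n1`, which differs from compound 1 by benzyl in place of 4,4-dimethylcyclohexyl on an aromatic nitrogen. With compound 1 itself only a limit, the expected step that the limit leaves unreadable from compound 1 to compound 4 rests on thin ground and no direction beyond the scatter is expected. Compound 4 is estimated at 35%, range 10% to 70%.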

Compound 4, largest response reached (Emax), in percent of the reference or control that the assay uses: 74%
For compound 4 the middle estimate is 39 percentage points below the measured one; the whole stated range lies below it.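

The step from compound 1 to compound 4 cannot be read, as compound 1 stands only as a limit of the assay. The compounds shown leave open how far benzyl and 4,4-dimethylcyclohexyl differ in this assay.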